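The source may hold more compounds than are shown below. What is called first, only, known or untested is meant among the compounds shown, and "the series" means these compounds.

Compound 1 `Cc1ccc2c(C3CCN(CCN4CCN(C(C)C)C4=O)CC3)cn(-c3ccc(Cl)cc3)c2c1` carries a chloro group on the ring attached to the shared core, and in an assay on cell membranes for displacement of a labelled ligand from Adrenergic receptor alpha-1 (Rattus norvegicus) (on this read-out higher numbers stand for weaker inhibition and lower numbers for stronger inhibition), compound 1 gives 450 nM. Compound 2 `Cc1ccc2c(C3CCN(CCN4CCN(C(C)C)C4=O)CC3)cn(-c3ccccc3)c2c1` has hydrogen there instead, and in this assay compound 2 gives 120 nM, the lower of the two numbers, the step being a 3.8-fold lower number from compound 1 to compound 2 (0.57 log units; beyond the scatter). Compound 3 `Cc1ccc2c(C3CCN(CCN4CCN(C(C)C)C4=O)CC3)cn(-c3ccccc3F)c2c1` is compound 2 with fluoro in place of hydrogen on an aromatic carbon. Within the data shown here, only that one step bears on this change, and it puts a halogen back onto the same ring, so a modest move toward a higher number is expected for compound 3, estimated at 180 nM, ranging from 80 nM to 400 nM, a step of a 1.5-fold higher number from compound 2 to compound 3 (0.18 log units; within the scatter).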

Compound 3, half-maximal inhibitory concentration: 370 nM
Estimate against measurement, compound 3: 2.1-fold (0.31 log units) below; the range from low to high includes it.
By their numbers in this assay, from the lowest: compound 2; then compounds 3 and 1 (each within the scatter of the next).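

Putting fluoro on the phenyl ring, ortho to a large group, gives a 3.1-fold higher number from compound 2 to compound 3 (0.49 log units; beyond the scatter), so in this assay a single added fluorine is enough to move the number beyond the scatter. Replacing 4-chlorophenyl with 2-fluorophenyl gives a 1.2-fold lower number from compound 1 to compound 3 (0.09 log units; within the scatter), so these two halogen-bearing rings cannot be told apart here, and both stand at higher numbers than the plain phenyl of compound 2. No supporting data bear on why this happens. On these data alone, whether 2-chlorophenyl or 4-fluorophenyl would match them remains open. So does whether a non-halogen group on this ring, such as methoxy or an amine, would also raise the number.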